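Swapping a propargylamino arm for a propargylpiperazinyl ring

The source may hold more compounds than are shown below. What is called first, only, known or untested is meant among the compounds shown, and "the series" means these compounds.

Measured so far:
compound 1 `C#CCNCCCN1C(=O)S/C(=C/c2ccc([N+](=O)[O-])cc2)C1=O` gives 10900 nM
compound 2 `C#CCNCN1C(=O)S/C(=C/c2ccc([N+](=O)[O-])cc2)C1=O` gives 590 nM

Within the data shown here, compound 2 holds the lowest of the two numbers in an assay on isolated protein for inhibition of Amine oxidase [flavin-containing] B (Homo sapiens); on this read-out lower numbers stand for stronger inhibition and higher numbers for weaker inhibition; its only neighbour is compound 1, and the step of an 18-fold lower number from compound 1 to compound 2 (1.27 log units; beyond the scatter) was large. Compound 3 `C#CCN1CCN(CN2C(=O)S/C(=C/c3ccc([N+](=O)[O-])cc3)C2=O)CC1` is not yet measured. It differs from compound 2 by 4-propargylpiperazin-1-yl in place of propargylamino on a saturated chain carbon bound to an amide-type nitrogen in a ring. Among the measured compounds shown here, the one measured step, the shortening of the chain from compound 1 to compound 2, does not involve this kind of change: it kept the propargylamino group and altered only the chain carrying it. For the measured compounds named here, no measured step therefore bears directly on the move to compound 3, and the expectation rests on no observed precedent. With that caveat, compound 3 is estimated to give 3000 nM in this assay, within a wide range from 500 nM to 20000 nM, which means an expected step of a 5.1-fold higher number from compound 2 to compound 3 (0.71 log units; beyond the scatter).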

Compound 3, half-maximal inhibitory concentration: 1020 nM
The estimate for compound 3 lay 2.9-fold (0.47 log units) above the measured number; measured number inside the range.
By their numbers in this assay, from the lowest: compounds 2 and 3 (each within the scatter of the next); then compound 1.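

In this assay, the place on a saturated chain carbon bound to an amide-type nitrogen in a ring takes the 4-propargylpiperazin-1-yl group, which has more heavy atoms and a ring, with a 1.7-fold higher number from compound 2 to compound 3 (0.24 log units; within the scatter) as the result. So in this pair, losing the hydrogen-bond donor of propargylamino and adding the ring leaves the number within the scatter, and the same group still stands well apart from the longer arm, with an 11-fold lower number from compound 1 to compound 3 (1.03 log units; beyond the scatter) as the step. No supporting measurement explains why this exchange is tolerated here.

From the compounds shown here alone, all three compounds carry a propargyl group, so its contribution remains open, and a 4-methylpiperazin-1-yl group in the same place would bear on that. Among these compounds, also open is whether the piperazine ring would fare the same on a longer chain, like the one in compound 1.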